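Aromatic Amide in Place of Aminoalkyl Amide on a Shared Core

This account rests on a few compounds, and the source may have more. Where it says the series, first, only, none or still open, it means among the compounds named here.

Compound 1 `C=CC(=O)Nc1cccc(-c2nc3ccccc3s2)c1` was tested in an ADME assay on HepG2 cells (Homo sapiens) for inhibition, with a stated time of 72 h (on this read-out lower numbers stand for an effect already at smaller amounts and higher numbers for an effect only at larger amounts of compound), where compound 1 returns only a limit of the assay, > 25000 nM. Compound 2 `C=C(C)C(=O)Nc1cccc(-c2nc3ccccc3s2)c1` also returns a limit in this assay, > 25000 nM. Within the data shown here, compound 3 `CN(C)CCC(=O)Nc1cccc(-c2nc3ccccc3s2)c1` is the single member of the set that returns a number in this assay, 21000 nM, so compound 3 stands as the only measured value, the rest of the set resting at the limit of > 25000 nM in this assay, at which 2 of the 3 values shown sit.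

Compound 4 `O=C(Nc1cccc(-c2nc3ccccc3s2)c1)c1cnccc1Cl` has not yet been measured; against compound 3 it changes (4-chloropyridin-3-yl in place of 2-(dimethylamino)ethyl on a carbonyl carbon). Three steps are known among the measured compounds. The two that lead to compound 3, an at least 1.1-fold lower number from compound 1 to compound 3 (0.07 log units; that floor lies within the scatter) and an at least 1.1-fold lower number from compound 2 to compound 3 (0.07 log units; that floor lies within the scatter), are only floors set by the limits, and a step that the two limits leave unreadable from compound 1 to compound 2 cannot be read at all. None of them involves an aromatic group on the carbonyl carbon, so nothing measured speaks to the size or direction of the present change. Compound 4 is therefore expected near the value of compound 3, at 20000 nM, with a range from 7000 nM to 40000 nM. The expected step of a 1.1-fold lower number from compound 3 to compound 4 (0.02 log units; within the scatter) is none beyond the scatter, and a reported limit rather than a number remains a real possibility for compound 4.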

Compound 4, half-maximal effective concentration: > 25000 nM
Compound 4 was reported as a limit (the forecaster's own chance of this, stated with the estimate: 45%); at least 1.2-fold (0.09 log units) between middle value and limit.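

With 4-chloropyridin-3-yl on the carbonyl carbon, an aromatic ring at this position can now be read in this assay, and it leaves compound 4 at a limit, as with the vinyl and 1-methylethenyl amides, so that compound 3 still holds the only number in the set: the limit of > 25000 nM in this assay, at which 3 of the 4 values shown sit.

The change of 2-(dimethylamino)ethyl to this ring gives an at least 1.1-fold higher number from compound 3 to compound 4 (0.07 log units; that floor lies within the scatter), which shows no change beyond the scatter, although a floor does not tell how large the true step is. The steps from compound 1 and from compound 2 to compound 4 cannot be read, as both ends of each are limits.

On these data alone, how far compound 1, compound 2 and compound 4 truly lie from compound 3 stays open, as does whether the number of compound 3 depends on its dimethylamino nitrogen. A plain phenyl ring or a pyridine without chlorine on the carbonyl carbon, or a longer aminoalkyl chain or a piperidine there, would be needed to tell whether any group at this position moves the read-out clear of the limit.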